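Methoxy on the cyclobutyl amide: clearance expectation for compound 4

A few compounds are considered here, and "the series" means these few. Any claim that something is new, unique, unknown or untested is made for them only; others in the source may bear on it.

Measured compounds:
compound 1, `CCn1c(-c2cnc(C)nc2)nc2c(N[C@H]3CCN(C(=O)C4CCC4)C3)ncnc21`: 30 mL/min/kg
compound 2, `CCn1c(-c2ccc(C(F)(F)F)nc2)nc2c(O[C@H]3CCN(C(=O)c4cocn4)C3)ncnc21`: 19 mL/min/kg
compound 3, `CCn1c(-c2ccc(C(F)(F)F)nc2)nc2c(O[C@H]3CCN(C(=O)N4CC(OC)C4)C3)ncnc21`: 46 mL/min/kg

In an ADME assay on the whole organism (Canis lupus familiaris, strain Beagle) for metabolic stability (on this read-out higher numbers stand for fast clearance and lower numbers for slow clearance), compound 1 sits among the numbers of compound 2 and compound 3, and its gaps to both fall within the usual scatter, so no order among the three can be read from these values.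

Compound 4, `CCn1c(-c2cnc(C)nc2)nc2c(N[C@H]3CCN(C(=O)[C@H]4C[C@@H](OC)C4)C3)ncnc21`, differs from compound 1 by methoxy in place of hydrogen on a saturated ring carbon. For the measured compounds named here, the only measured step, a 2.4-fold higher number from compound 2 to compound 3 (0.38 log units; beyond the scatter), exchanges a whole ring on the carbonyl carbon rather than adding a methoxy to a saturated ring, so it does not bear directly on this change. Going by the values given here, with no comparable step in hand, the expectation for compound 4 is a step of a 1.1-fold lower number from compound 1 to compound 4 (0.03 log units; within the scatter), that is none beyond the scatter. Compound 4 is therefore estimated at 28 mL/min/kg, within 14 mL/min/kg to 56 mL/min/kg.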

Compound 4, clearance: 13 mL/min/kg
For compound 4 the middle estimate is 2.2-fold (0.33 log units) above the measured one, and the stated range ends above it.
By their numbers in this assay, from the lowest: compounds 4, 2, 1 and 3 (each within the scatter of the next, the first and the last beyond it).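

In this assay the cyclobutyl amide proves sensitive at this position: methoxy in place of hydrogen on a saturated ring carbon gives a 2.3-fold lower number from compound 1 to compound 4 (0.36 log units; beyond the scatter) and so moves clearance lower, beyond the scatter. For the compounds shown here, this is the first single-place step to go in that direction, and it comes from adding only 2 heavy atoms, without exchanging a ring. Nothing at hand explains the step.

Open, on these data alone, is whether hydroxy or ethoxy on the same ring carbon would give a step of similar size. Also open, as far as these compounds go, is whether the change would carry over to the amide of compound 2 or compound 3.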